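One Chloro Removed: What to Expect for Compound 3

The compounds below may be only part of what the source reports. "The series", "measured", "known", "first", "only" and "open" are said of these compounds alone.

Compound 1 `ClCc1ccc(Cn2cnc3c(Cl)ncnc32)cc1` provides the only measured point of this set: in a functional assay on A549 cells (Homo sapiens) for cytotoxicity, read by sulforhodamine B assay, with a stated time of 48 h (a higher number here means that more compound is tolerated, a lower number that less compound is tolerated), compound 1 gives 51300 nM. Compound 2 `ClCc1ccccc1Cn1cnc2c(Cl)nc(Cl)nc21` carries a second chloro on its core, yet in this assay compound 2 stands at "not determined" (no result reported), with no result reported, so there is no number on which compound 2 stands. Compound 3 `ClCc1ccccc1Cn1cnc2c(Cl)ncnc21` is reached from compound 2 by the change (hydrogen in place of chloro on an aromatic carbon), hydrogen in place of chloro on an aromatic carbon. Among the measured compounds shown here, because compound 2 was not measured, no step within this group can be set beside that change, and neither the size nor the direction of its effect in this assay can be read from a measured pair; the only anchor is compound 1, which shares the core of compound 3 and differs from it elsewhere. On that basis alone, compound 3 is expected to give about 50000 nM in this assay, with a range from 15000 nM to 160000 nM, an estimate that rests more on compound 1 than on the step from compound 2 itself.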

Compound 3, concentration lethal to 50% of the cells: 75900 nM
For compound 3 the middle estimate is 1.5-fold (0.18 log units) below the measured one, within the range that was stated.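

No new step can be read from compound 3: compound 2, which differs from it in one place, has no number to set against it in this assay. The compounds shown leave open what hydrogen in place of chloro on that aromatic carbon does in this assay. Nothing available bears on the result for compound 3.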